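Compound 2 to Compound 3 Under a Cell Growth Read-out

The compounds below may be only part of what the source reports. "The series", "measured", "known", "first", "only" and "open" are said of these compounds alone.

Two compounds have so far been run in a functional assay on A549 cells (Homo sapiens) for inhibition, read by sulforhodamine B assay, with a stated time of 48 h; on this read-out higher numbers stand for lower toxicity in this test and lower numbers for higher toxicity in this test. Compound 1 `COc1ccc(-c2cc(/C=C/C(=O)c3ccc(OC)c(OC)c3)[nH]n2)cc1` reaches only the limit of the measurement: in this assay compound 1 gives > 100000 nM, a limit rather than a number. Compound 2 `COc1cc(-c2cc(/C=C/C(=O)c3ccc(Cl)c(Cl)c3)[nH]n2)cc(OC)c1OC` likewise stops at a limit, giving > 100000 nM in this assay. Compound 2 therefore stands where (the limit of > 100000 nM in this assay, at which 2 of the 2 values shown sit), and no number separates it from compound 1, so nothing can be said of any order between the two.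

Compound 3 `COc1cc(-c2cc(/C=C/C(=O)c3ccc(F)c(F)c3)[nH]n2)cc(OC)c1OC` has not yet been measured. It differs from compound 2 by 3,4-difluorophenyl in place of 3,4-dichlorophenyl on a carbonyl carbon.

Going by the values given here, no measured step between two compounds exists to lean on. The expected step is a step that the limit leaves unreadable from compound 2 to compound 3, none beyond the scatter, since compound 2 itself shows only a limit. Compound 3 is accordingly estimated at 150000 nM, within 70000 nM to 400000 nM, and most likely again reported only as a limit.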

Compound 3, concentration lethal to 50% of the cells: > 100000 nM
Compound 3: only a limit was reported; the forecaster's own chance of this, stated with the estimate: 85%; the middle value is on the limit's open side.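

In this assay compound 3 gives > 100000 nM as a limit and not a number. Going by these compounds alone, compound 2 also stops at a limit, so no step from compound 2 to compound 3 can be read. The compounds shown leave open whether any change to the shared core brings a value inside the measured range: the limit of > 100000 nM in this assay, at which 3 of the 3 values shown sit.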